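Ring nitrogen substituent in the shared core: acetyl replaces cyclohexyl

A few compounds are considered here, and "the series" means these few. Any claim that something is new, unique, unknown or untested is made for them only; others in the source may bear on it.

Compound 3 `C(#Cc1nc2c(s1)CN(C1CCCCC1)CC2)c1ccccc1` stands at the edge of an assay on HEK293 cells for positive allosteric modulation of metabotropic glutamate receptor 5 (Homo sapiens), read by FLIPR, with a stated time of 1 h; on this read-out lower numbers stand for an effect already at smaller amounts and higher numbers for an effect only at larger amounts of compound: its value > 10000 nM is a limit of the assay, not a number. Compound 2 `CCN1CCc2nc(C#Cc3ccccc3)sc2C1` likewise reports only a limit, > 10000 nM. Compound 1 `CN1CCc2nc(C#Cc3ccccc3)sc2C1` alone gives a number, 34 nM. Because of the limit of > 10000 nM in this assay, at which 2 of the 3 values shown sit, both steps away from it read as large, an at least 290-fold higher number from compound 1 to compound 2 (2.46 log units; beyond the scatter) and an at least 290-fold higher number from compound 1 to compound 3 (2.46 log units; beyond the scatter), while the step that the two limits leave unreadable from compound 2 to compound 3 cannot be sized. Compound 4 `CC(=O)N1CCc2nc(C#Cc3ccccc3)sc2C1` differs from compound 3 by acetyl in place of cyclohexyl on an amine nitrogen in a ring. Among the measured compounds shown here, no measured step covers acetyl on this nitrogen; the two measured steps only show the number rising whenever methyl is exchanged. Compound 4 is therefore expected near 3000 nM, within 300 nM to 10000 nM. The step of an at least 3.3-fold lower number from compound 3 to compound 4 (0.52 log units; beyond the scatter) is the expected consequence, though starting from a limit it may itself stay unreadable.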

Compound 4, half-maximal effective concentration: > 10000 nM
Compound 4 was reported as a limit; the forecaster's own chance of this, stated with the estimate: 50%; middle value at least 3.3-fold (0.52 log units) away from the limit.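

In this assay, acetyl in place of methyl on the amine nitrogen in a ring gives an at least 290-fold higher number from compound 1 to compound 4 (2.46 log units; beyond the scatter). Acetyl, which brings a hydrogen-bond acceptor that ethyl and cyclohexyl lack, still gives no number, so among the groups shown on this nitrogen only methyl does. The steps among compounds 2, 3 and 4 cannot be read, and their order stays unknown: the limit of > 10000 nM in this assay, at which 3 of the 4 values shown sit.

As far as these compounds go, whether the secondary amine with hydrogen on this nitrogen, or a formyl group, would give a number stays open. So does whether any group larger than methyl can do so here.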